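Changing the group on a carbonyl carbon

The source may report more compounds than this note shows. Statements on the series, on what has been measured and on what is new or still open speak of the compounds shown alone.

Compound 1 `Cc1c(-c2ccc(-c3ccccc3F)cc2)nc2ccc(F)cc2c1C(=O)C(F)(F)F` gives > 3000 nM (a limit)
Compound 2 `COC(=O)NC(=O)c1c(C)c(-c2ccc(-c3ccccc3F)cc2)nc2ccc(F)cc12` gives 403 nM
Compound 3 `CCONC(=O)c1c(C)c(-c2ccc(-c3ccccc3F)cc2)nc2ccc(F)cc12` gives 33 nM

In a functional assay on MOLM-13 cells (Homo sapiens) for antiproliferative activity (on this read-out higher numbers stand for weaker inhibition and lower numbers for stronger inhibition), compound 3 holds the lowest number (33 nM), well clear of compound 2 (403 nM). The value of compound 1 is only a limit. Compound 4 `Cc1c(-c2ccc(-c3ccccc3F)cc2)nc2ccc(F)cc2c1C(=O)N(C)O` carries hydroxy(methyl)amino in place of ethoxyamino on a carbonyl carbon. Three measured steps changed the group at this place, all beyond the scatter: (an at least 7.4-fold lower number from compound 1 to compound 2 (0.87 log units; beyond the scatter)), (a 12-fold lower number from compound 2 to compound 3 (1.09 log units; beyond the scatter)) and (an at least 90-fold lower number from compound 1 to compound 3 (1.95 log units; beyond the scatter)). None of them tests the entering group, and compound 3 already sits lowest (33 nM). For compound 4 a step towards a higher number, beyond the scatter, is therefore expected (a 3.0-fold higher number from compound 3 to compound 4 (0.48 log units; beyond the scatter)). Compound 4 is estimated at 100 nM (expected range 25 nM to 500 nM).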

Compound 4, half-maximal inhibitory concentration: 5100 nM
Compound 4: middle estimate off by 51-fold (1.71 log units), on the low side; the measured number lies above the stated range.
By their numbers in this assay, from the lowest: compound 3; then compound 2; then compound 4.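

In this assay, swapping ethoxyamino for hydroxy(methyl)amino on this carbonyl carbon proves a drastic change (a 150-fold higher number from compound 3 to compound 4 (2.19 log units; beyond the scatter)), although neither group carries a ring or a net charge. Compound 4 also trails the (methoxycarbonyl)amino compound (a 13-fold higher number from compound 2 to compound 4 (1.10 log units; beyond the scatter)), so a nitrogen on this carbonyl carbon does not by itself secure a low number, with compound 4 going against compound 2 and compound 3. The step from compound 1 to compound 4 cannot be read, because compound 1 carries only a limit: (the limit of > 3000 nM in this assay, at which 1 of the 4 values shown sits)

The compounds shown do not separate the methyl on the nitrogen from the hydroxy group. On these data alone, how methylamino or propoxyamino would read at this carbonyl carbon stays open.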